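Adding a Second Hydroxy to the Aromatic Ring

A few compounds are considered here, and "the series" means these few. Any claim that something is new, unique, unknown or untested is made for them only; others in the source may bear on it.

Three acylated compounds sharing one core have been examined in a functional assay on HeLa cells (Homo sapiens) for cytotoxicity, read by MTT assay, with a stated time of 2 days; a lower number here means a stronger inhibitor, a higher number a weaker inhibitor. Compound 1 `CC(=O)OC[C@H]1O[C@H](O[C@]2(COC(C)=O)O[C@H](CO)[C@@H](O)[C@@H]2OC(=O)/C=C/c2ccc(O)cc2)[C@H](OC(C)=O)[C@@H](O)[C@@H]1O` gives 2490 nM. Compound 2 `CC(=O)OC[C@H]1O[C@H](O[C@]2(CO)O[C@H](CO)[C@@H](O)[C@@H]2OC(=O)/C=C/c2ccc(O)cc2)[C@H](O)[C@@H](OC(C)=O)[C@@H]1OC(C)=O` gives 3800 nM, a number that lies within the usual scatter of the value for compound 1, so these two cannot be told apart. Compound 3 `CC(=O)OC[C@H]1O[C@H](O[C@]2(COC(C)=O)O[C@H](CO)[C@@H](OC(C)=O)[C@@H]2OC(=O)/C=C/c2ccc(O)cc2)[C@H](O)[C@@H](O)[C@@H]1O` gives 110 nM, a far lower number than compound 1, with the gap well beyond the scatter. Compound 1 thus stands, together with compound 2, at the higher end of the three numbers and far from compound 3.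

Compound 4 `CC(=O)OC[C@H]1O[C@H](O[C@]2(COC(C)=O)O[C@H](CO)[C@@H](O)[C@@H]2OC(=O)/C=C/c2ccc(O)c(O)c2)[C@H](OC(C)=O)[C@@H](O)[C@@H]1O` is compound 1 with a single change: hydroxy in place of hydrogen on an aromatic carbon. Going by the values given here, no measured pair among the three compounds shows this change, so its effect is unknown from the data at hand. The expected step is a 1.7-fold lower number from compound 1 to compound 4 (0.22 log units; within the scatter), a modest move toward a lower number that may not clear the scatter. Compound 4 is therefore estimated at 1500 nM, with a likely range from 500 nM to 5000 nM.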

Compound 4, half-maximal inhibitory concentration: 1090 nM
Compound 4: the middle estimate sits 1.4-fold (0.14 log units) above what was measured, and the stated range covers the measured number.
By their numbers in this assay, from the lowest: compound 3; then compound 4; then compounds 1 and 2 (each within the scatter of the next).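

In this assay, going by these compounds alone, the change from 4-hydroxyphenyl to 3,4-dihydroxyphenyl gives a 2.3-fold lower number from compound 1 to compound 4 (0.36 log units; beyond the scatter) as the first step that can be read at a single place, as no two earlier compounds differed in one place only. It shows that this aromatic carbon, ortho to a hydroxy group and meta to a large group, is not silent: hydroxy in place of hydrogen here moves the number modestly but clears the scatter.

Still open, as far as these compounds go, is whether a methoxy group, an amine or a fluorine on this same carbon would shift the number as far, and whether the step would hold on the acetyl patterns of compound 2 and compound 3. Nothing at hand explains why the number moves.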